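The source may report more compounds than this note shows. Statements on the series, on what has been measured and on what is new or still open speak of the compounds shown alone.

Measured compounds:
- compound 1, `CCOc1cc([C@H]2SCC(=O)N2NC(=O)c2nccnc2N)ccc1O`: > 100 ug/mL
- compound 2, `Cc1cnc(C(=O)NN2C(=O)CS[C@@H]2c2ccc([N+](=O)[O-])cc2)cn1`: > 100 ug/mL
- compound 3, `O=C(NN1C(=O)CS[C@@H]1c1ccc(Cl)cc1)c1cnccn1`: > 100 ug/mL

All three share a core and were read in an ADME assay on PANC-1 cells (Homo sapiens) for cytotoxicity, read by MTT assay, with a stated time of 5 days; on this read-out higher numbers stand for weaker inhibition and lower numbers for stronger inhibition. The value of compound 1 is a limit of the assay, not a number. The value of compound 2 is likewise a limit. For compound 3 the figure is also a limit; no numeric potency is known for it, and all three values sit at the limit of > 100 ug/mL in this assay, at which 3 of the 3 values shown sit, so no ordering among them can be drawn.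

Compound 4, `O=C(NN1C(=O)CS[C@@H]1c1ccc([N+](=O)[O-])cc1)c1cnccn1`, awaits measurement in this assay. It differs from compound 3 by nitro in place of chloro on an aromatic carbon. Compound 2 also carries the nitro group and reached only the same limit. Within the data shown here, no step between measured compounds is available; no change beyond the scatter is expected from compound 3 to compound 4, and the step that the limit leaves unreadable from compound 3 to compound 4 is an estimate only. Compound 4 is expected at 150 ug/mL, within 60 ug/mL to 400 ug/mL, most likely again reported as a limit.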

Compound 4, half-maximal inhibitory concentration: > 100 ug/mL
Compound 4 was reported as a limit; the forecaster's own chance of this, stated with the estimate: 80%; the middle value does not contradict the limit.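

Among these compounds, no step to compound 4 can be read from compound 3 or compound 2 in this assay, because every value shown is a limit: the limit of > 100 ug/mL in this assay, at which 4 of the 4 values shown sit. The compounds shown leave open whether any change on the shared core gives a numeric value in this assay.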